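From fluoro to trifluoromethyl: working notes on compound 4

The compounds below may be only part of what the source reports. "The series", "measured", "known", "first", "only" and "open" are said of these compounds alone.

Values in a functional assay on MCF7 cells (Homo sapiens) for antiproliferative activity, read by MTT assay, with a stated time of 24 h; on this read-out lower numbers stand for stronger inhibition and higher numbers for weaker inhibition:
- compound 1 `FC(F)(F)c1ccc(-c2nn(-c3ccccc3)cc2-c2nc3ccccc3[nH]2)cc1`: 6330 nM
- compound 2 `COc1ccc(S(=O)(=O)n2c(-c3cn(-c4ccccc4)nc3-c3ccc(F)cc3)nc3ccccc32)cc1`: 530 nM
- compound 3 `O=S(=O)(c1ccc(C(F)(F)F)cc1)n1c(-c2cn(-c3ccccc3)nc2-c2ccc(F)cc2)nc2ccccc21`: 1580 nM

Among these three, compound 2 gives the lowest number, and both other compounds lie beyond the scatter from it. The next step to consider leads to compound 4 `COc1ccc(S(=O)(=O)n2c(-c3cn(-c4ccccc4)nc3-c3ccc(C(F)(F)F)cc3)nc3ccccc32)cc1`, which has not yet been measured. The change is trifluoromethyl in place of fluoro on an aromatic carbon, turning 4-fluorophenyl into 4-(trifluoromethyl)phenyl.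

Among the compounds with values here, no measured step makes this exact change. The nearest evidence is a 3.0-fold higher number from compound 2 to compound 3 (0.47 log units; beyond the scatter), a modest rise in the number when trifluoromethyl replaces methoxy, but at a different place in the molecule. Compound 1, at 6330 nM, carries 4-(trifluoromethyl)phenyl too, but it differs from compound 4 in more than this one place, so its value cannot isolate the change. With a single indirect step to go on, a modest move towards a higher number is expected in this assay, and a move within the scatter remains possible. The estimated change is a 1.6-fold higher number from compound 2 to compound 4 (0.21 log units; within the scatter). The expected value for compound 4 is 850 nM, with an estimated range of 320 nM to 2300 nM.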

Compound 4, half-maximal inhibitory concentration: 420 nM
Compound 4: the middle estimate sits 2.0-fold (0.31 log units) above what was measured; low and high end bracket the measured number.
By their numbers in this assay, from the lowest: compounds 4 and 2 (each within the scatter of the next); then compound 3; then compound 1.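

In this assay, within the data shown here, turning 4-fluorophenyl into 4-(trifluoromethyl)phenyl gives a 1.3-fold lower number from compound 2 to compound 4 (0.10 log units; within the scatter) and so provides the first direct reading at this position: with (4-methoxyphenyl)sulfonyl in place, the two groups cannot be told apart in this assay. Among these compounds, the same compound also gives the first one-place reading of the sulfonyl group, with a 15-fold lower number from compound 1 to compound 4 (1.18 log units; beyond the scatter) when (4-methoxyphenyl)sulfonyl replaces hydrogen on the aromatic nitrogen and 4-(trifluoromethyl)phenyl stays fixed, so the large step in this pair belongs to the nitrogen substituent and not to the aromatic carbon that carries fluoro or trifluoromethyl. No supporting measurement is available to explain either step.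

The series shown has only fluoro and trifluoromethyl on this aromatic carbon, so it remains open whether an amine, a carboxylic acid or a longer chain there would also leave the number within the scatter. As far as these compounds go, it is also open whether the flat result at this position holds with a sulfonyl group other than (4-methoxyphenyl)sulfonyl on the nitrogen.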